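Anilide in place of benzylamide: expected loss of potency

The source may hold more compounds than are shown below. What is called first, only, known or untested is meant among the compounds shown, and "the series" means these compounds.

Within the data shown here, compound 3 `COc1ccc2c(=O)c(/C=C/C(=O)NCc3ccccc3)coc2c1` is the one compound of the three with a measured number in a functional assay on HeLa cells (Homo sapiens) for inhibition, read by MTT assay, with a stated time of 48 h; a higher number here means a weaker inhibitor, a lower number a stronger inhibitor: compound 3 gives 33400 nM. Compound 1 `COc1ccc2c(=O)c(/C=C/C(=O)Nc3cccc(C)c3)coc2c1` reaches only a limit of the assay, > 100000 nM. Compound 2 `COc1ccc(CNC(=O)/C=C/c2coc3cc(O)ccc3c2=O)cc1`, which carries a hydroxyl on the shared core and a 4-methoxybenzyl on the amide nitrogen, also reaches only a limit, > 100000 nM. Among the measured compounds shown here, the one measured step that changes the group on the amide nitrogen alone is an at least 2.9-fold lower number from compound 1 to compound 3 (0.47 log units; beyond the scatter), so the benzyl amide is the stronger of that pair; two of three values sit at the limit of > 100000 nM in this assay, at which 2 of the 3 values shown sit.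

Compound 4 `COc1cccc(NC(=O)/C=C/c2coc3cc(OC)ccc3c2=O)c1` differs from compound 3 in that (3-methoxyphenyl in place of benzyl on an amide-type nitrogen). This returns to an aryl group directly on the amide nitrogen, as in compound 1, now with a methoxy instead of a methyl. Compound 4 is therefore expected to show a 3.0-fold higher number from compound 3 to compound 4 (0.48 log units; beyond the scatter) in this assay, a weaker inhibitor, and quite possibly only a limit again. The estimate for compound 4 is 100000 nM, with a range from 33000 nM to 300000 nM.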

Compound 4, half-maximal inhibitory concentration: 19200 nM
The estimate for compound 4 lay 5.2-fold (0.72 log units) above the measured number; the whole stated range lies above it.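

In this assay the change from benzyl to 3-methoxyphenyl on the amide nitrogen gives a 1.7-fold lower number from compound 3 to compound 4 (0.24 log units; within the scatter) and so an aryl group placed directly on that nitrogen does not by itself cost activity, which compound 1 alone could not show. Among the two aryl amides, methoxy in place of methyl on an aromatic carbon gives an at least 5.2-fold lower number from compound 1 to compound 4 (0.71 log units; beyond the scatter) and this is the first sign that the small group on that ring counts, not only the benzyl or aryl choice. Compound 1 sits at a limit of the assay (> 100000 nM) and that step therefore gives only a lower bound on the true size of the change.

On these data alone, with a single aryl amide giving a number, it stays open whether methoxy is special or whether other groups would serve as well. An amine or a carboxylic acid in place of the methoxy remains an untested question in what is shown here.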